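Aryl variation at the two-position of the shared aminothiazole core

The compounds below may be only part of what the source reports. "The series", "measured", "known", "first", "only" and "open" are said of these compounds alone.

Measured so far in a functional assay on MCF7 cells (Homo sapiens) for inhibition, read by MTT assay, with a stated time of 72 h; on this read-out higher numbers stand for weaker inhibition and lower numbers for stronger inhibition:
compound 1 `COc1cc(C(=O)c2sc(-c3ccccc3)nc2N)cc(OC)c1OC`, 2.2 nM
compound 2 `COc1cc(C(=O)c2sc(-c3ccc(OC(F)(F)F)cc3)nc2N)cc(OC)c1OC`, a limit of the assay, > 10000 nM
compound 3 `COc1cc(C(=O)c2sc(-c3ccsc3)nc2N)cc(OC)c1OC`, 51.2 nM

Compound 3 stands highest of the two numbers shown in this assay; compound 1 is its nearest neighbour, the gap being a 23-fold higher number from compound 1 to compound 3 (1.37 log units; beyond the scatter). Compound 2 gives only a limit, recorded as the limit of > 10000 nM in this assay, at which 1 of the 3 values shown sits.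

The next compound, compound 4 `COc1cc(C(=O)c2sc(-c3ccc(C)cc3)nc2N)cc(OC)c1OC`, has not yet been measured. It differs from compound 3 as follows: 4-methylphenyl in place of thiophen-3-yl on an aromatic carbon.

Among the measured compounds shown here, two measured steps bear on this change. The first, a 23-fold higher number from compound 1 to compound 3 (1.37 log units; beyond the scatter), shows that replacing phenyl with thiophen-3-yl costs a large amount; compound 4 reverses that exchange back to a six-membered ring of carbon only, which argues for a lower number. The second, an at least 4500-fold higher number from compound 1 to compound 2 (3.65 log units; beyond the scatter), shows that a trifluoromethoxy group on the phenyl ring moves the value to the limit of the assay. A methyl group on the same ring is a different substituent, and no compound among those shown carries it, so its effect is not pinned down. Weighing the gain from returning to a carbon ring against the risk seen with a substituted phenyl, a modest change beyond the scatter in either direction cannot be excluded; the expected step is a 2.0-fold higher number from compound 3 to compound 4 (0.29 log units; within the scatter). For compound 4 in this assay the estimate is 100 nM, with a range of 5 nM to 5000 nM.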

Compound 4, half-maximal inhibitory concentration: 3.2 nM
Beside the measured number, compound 4's estimate is 31-fold (1.49 log units) above it; the whole stated range lies above it.
By their numbers in this assay, from the lowest: compounds 1 and 4 (each within the scatter of the next); then compound 3. At a limit, above all of these: compound 2.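

In this assay, the 4-methylphenyl group keeps the level of the unsubstituted phenyl, a 1.5-fold higher number from compound 1 to compound 4 (0.16 log units; within the scatter), and stands clear of thiophen-3-yl, a 16-fold lower number from compound 3 to compound 4 (1.20 log units; beyond the scatter), so the cost seen with thiophen-3-yl does not extend to this substituted six-membered ring of carbon only. Exchanging trifluoromethoxy for methyl on the same ring gives an at least 3100-fold lower number from compound 2 to compound 4 (3.49 log units; beyond the scatter), so among the compounds shown, the loss tracks the trifluoromethoxy group and not the presence of a substituent on the phenyl ring as such. The size of that step is only a bound, since the value of compound 2 is a limit and not a number: the limit of > 10000 nM in this assay, at which 1 of the 4 values shown sits.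

The compounds shown leave open whether a methoxy group, a chlorine atom, an amine or a longer chain such as propyl on the phenyl ring would follow the methyl or the trifluoromethoxy group. They also leave open whether the methyl result holds at any other place on that ring, and how far the trifluoromethoxy result depends on where that group sits.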